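The compounds below may be only part of what the source reports. "The series", "measured", "known", "first", "only" and "open" are said of these compounds alone.

In an ADME assay on MDCKII-LE cells (Canis lupus familiaris) for permeability (a higher number here means that the compound crosses the layer faster, a lower number that the compound crosses the layer more slowly), two compounds on the shared core have been measured so far. Compound 1 `Cc1cnc(NC(=O)c2cc(Oc3ccc(C(=O)N(C)C)cc3)c3cn(C)nc3c2)cn1` gives 14.6 10^-6 cm/s and compound 2 `Cc1cnc(NC(=O)c2cc(Oc3ccc(S(C)(=O)=O)cc3)c3cn(C)nc3c2)cn1` gives 20.4 10^-6 cm/s, so compound 2 stands level with compound 1 within the scatter. Compound 3 `CCS(=O)(=O)c1ccc(Oc2cc(C(=O)Nc3cnc(C)cn3)cc3nn(C)cc23)cc1` is the next entry. Its difference from compound 2 is methyl in place of hydrogen on a saturated chain carbon bound to a sulfonyl sulfur, so methylsulfonyl becomes ethylsulfonyl. For the measured compounds named here, only one measured step bears on this: a 1.4-fold higher number from compound 1 to compound 2 (0.15 log units; within the scatter), methylsulfonyl in place of dimethylcarbamoyl on an aromatic carbon. Going by the values given here, that exchange concerns the same substituent but is a larger one, and the data contain no direct precedent for chain extension. No step beyond the scatter is therefore expected in this assay, and no direction can be assigned. The expected change is a 1.0-fold lower number from compound 2 to compound 3 (0.01 log units; within the scatter). Compound 3 is estimated at 20 10^-6 cm/s, with an expected range of 11 10^-6 cm/s to 34 10^-6 cm/s.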

Compound 3, apparent permeability: 10.6 10^-6 cm/s
Compound 3: middle estimate off by 1.9-fold (0.28 log units), on the high side; the measured number lies below the stated range.
By their numbers in this assay, from the lowest: compounds 3, 1 and 2 (each within the scatter of the next).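

In this assay, for the compounds shown here, this is the first reading of methyl in place of hydrogen on a saturated chain carbon bound to a sulfonyl sulfur, and methylsulfonyl to ethylsulfonyl gives a step that lies within the scatter (a 1.9-fold lower number from compound 2 to compound 3 (0.28 log units; within the scatter)). The step between the other two groups also lies within the scatter (a 1.4-fold lower number from compound 1 to compound 3 (0.14 log units; within the scatter)), so dimethylcarbamoyl, methylsulfonyl and ethylsulfonyl cannot be told apart at this position in this assay. No measurement shown offers an explanation for these numbers.

Still open, on these data alone, is whether a longer chain on the sulfonyl sulfur, such as propyl or butyl, would give a step beyond the scatter. Also open, as far as these compounds go, is how a group of another kind at this place, such as an amine or a carboxylic acid, would read in this assay.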